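Disulfonyl piperidine series: methylcarbamoyl replacing the oxadiazole

This account rests on a few compounds, and the source may have more. Where it says the series, first, only, none or still open, it means among the compounds named here.

Measured compounds:
Compound 1, `CCN(CC)S(=O)(=O)c1ccc(S(=O)(=O)N2CCC[C@@H](C(=O)N[C@@H]3CCN(C(=O)OC(C)(C)C)C3)C2)cc1`: in a functional assay on MIA PaCa-2 cells (Homo sapiens) for inhibition, read by MTT assay, with a stated time of 3 days (a lower number here means a stronger inhibitor, a higher number a weaker inhibitor), compound 1 gives > 10000 nM, which is a limit of the assay and not a number.
Compound 2, `CCN(CC)S(=O)(=O)c1ccc(S(=O)(=O)N2CCC[C@@H](C(=O)NC3COC3)C2)cc1`: in this assay compound 2 gives > 10000 nM, again a limit.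
Compound 3, `CCN(CC)S(=O)(=O)c1ccc(S(=O)(=O)N2CCC[C@@H](c3nc(C)no3)C2)cc1`: in this assay compound 3 gives > 10000 nM, also a limit.

Compound 3 therefore stands at the limit, and the other two values sit at the same limit, as the limit of > 10000 nM in this assay, at which 3 of the 3 values shown sit, records. The step that the two limits leave unreadable from compound 1 to compound 2 and the step that the two limits leave unreadable from compound 2 to compound 3 cannot be read in size or direction, since both ends of each are limits.

Compound 4, `CCN(CC)S(=O)(=O)c1ccc(S(=O)(=O)N2CCC[C@@H](C(=O)NC)C2)cc1`, carries the change (methylcarbamoyl in place of 3-methyl-1,2,4-oxadiazol-5-yl on a saturated ring carbon). Within the data shown here, no measured step touches this position with a readable value, so nothing bears on it beyond the shared limit. Every measured analogue here has stayed at the limit, and there is no sign that the change toward a smaller amide-type group would move the series out of that region.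

Compound 4 is expected to stay near the limit, with an estimated step that the limit leaves unreadable from compound 3 to compound 4 that is not expected to exceed the scatter. Compound 4 is estimated at 15000 nM in this assay, within 5000 nM to 50000 nM.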

Compound 4, half-maximal inhibitory concentration: > 10000 nM
Compound 4: a limit, no number (the forecaster's own chance of this, stated with the estimate: 85%); the middle value does not contradict the limit.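

In this assay compound 4 gives > 10000 nM, a limit and not a number, and the steps to compound 4 from compound 1, compound 2 and compound 3 cannot be read. The series stands at one shared limit: the limit of > 10000 nM in this assay, at which 4 of the 4 values shown sit.

The compounds shown leave open whether any change at this position gives a measurable value.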